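The source may hold more compounds than are shown below. What is called first, only, known or untested is meant among the compounds shown, and "the series" means these compounds.

Three related compounds share one core and were tested in a functional assay on A549 cells (Homo sapiens) for antiproliferative activity, read by MTT assay, with a stated time of 48 h; a lower number here means a stronger inhibitor, a higher number a weaker inhibitor. Compound 1, `O=C(/C=C\Nc1ccc(O)cc1)c1cn(-c2ccccc2)nc1-c1ccc(F)cc1`, gives 1500 nM. Compound 2, `COc1ccc(N/C=C\C(=O)c2cn(-c3ccccc3)nc2-c2ccc(F)cc2)cc1`, carries a single change, (methyl in place of hydrogen on an oxygen on an aromatic ring), and in this assay compound 2 gives 8900 nM; this step, a 5.9-fold higher number from compound 1 to compound 2 (0.77 log units; beyond the scatter), is the only clear movement in the set. Compound 3, `O=C(/C=C\Nc1ccc(O)cc1)c1cn(-c2ccccc2)nc1-c1ccc(Cl)cc1`, differs from compound 1 by chloro in place of fluoro on an aromatic carbon, and in this assay compound 3 gives 1910 nM. Since the step of a 1.3-fold higher number from compound 1 to compound 3 (0.10 log units; within the scatter) stays within the ordinary spread of repeated measurements, the numbers for compound 1 and compound 3 cannot be told apart with confidence.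

Compound 4, `COc1ccc(N/C=C\C(=O)c2cn(-c3ccccc3)nc2-c2ccc(Cl)cc2)cc1`, has not been measured. Within the data shown here, it is to compound 3 what compound 2 is to compound 1: the change methyl in place of hydrogen on an oxygen on an aromatic ring is the same as the one seen between compound 1 and compound 2, made on the same place. The change of the core between the two pairs is chloro in place of fluoro on an aromatic carbon. Because a 5.9-fold higher number from compound 1 to compound 2 (0.77 log units; beyond the scatter) weakened the inhibitor clearly, a step of similar size is expected for compound 4, a 5.8-fold higher number from compound 3 to compound 4 (0.76 log units; beyond the scatter). Compound 4 is therefore estimated at 11000 nM, with a likely range from 5000 nM to 25000 nM.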

Compound 4, half-maximal inhibitory concentration: 6460 nM
Compound 4: middle estimate off by 1.7-fold (0.23 log units), on the high side; the range from low to high includes it.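

In this assay, methoxy in place of hydroxy again gives a weaker inhibitor on the chloro core, with a 3.4-fold higher number from compound 3 to compound 4 (0.53 log units; beyond the scatter), and this step cannot be told apart from the one on the fluoro core: the same change on two cores in this assay, a 5.9-fold higher number (0.77 log units; beyond the scatter) from compound 1 to compound 2 and a 3.4-fold higher number (0.53 log units; beyond the scatter) from compound 3 to compound 4, 1.8-fold (0.24 log units) apart, within the scatter of two such steps. Chloro in place of fluoro, seen from the methoxy side, gives a 1.4-fold lower number from compound 2 to compound 4 (0.14 log units; within the scatter), so it again leaves the number within the ordinary spread of repeated measurements, and the two halogen steps also agree: the same change on two cores in this assay, a 1.3-fold higher number (0.10 log units; within the scatter) from compound 1 to compound 3 and a 1.4-fold lower number (0.14 log units; within the scatter) from compound 2 to compound 4, 1.8-fold (0.24 log units) apart, within the scatter of two such steps. Together these results show that the methoxy penalty carried over between these two closely related cores, but two pairs differing only in one halogen cannot show that it would hold on a more different core, and they do not explain why the step occurs.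

The compounds shown leave open whether a longer chain on that oxygen, such as ethoxy, would cost as much as methyl, or how an amine in place of the hydroxy would behave. They also leave open whether the same step would appear with bromo or a methyl group in place of the halogen.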